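The source may report more compounds than this note shows. Statements on the series, on what has been measured and on what is new or still open speak of the compounds shown alone.

Measured in a functional assay on MCF7 cells (Homo sapiens) for antiproliferative activity, read by MTT assay, with a stated time of 48 h; on this read-out higher numbers stand for weaker inhibition and lower numbers for stronger inhibition: compound 1 `CCOC(=O)CN(Cc1ccccc1)c1nc(NCc2cccc(OC)c2)ncc1[N+](=O)[O-]` gives 57400 nM. Compound 2 `CCOC(=O)CN(Cc1ccccc1)c1nc(Nc2cc(OC)c(OC)c(OC)c2)ncc1[N+](=O)[O-]` gives only the assay limit > 100000 nM. Compound 3 `CCOC(=O)CN(Cc1ccccc1)c1nc(Nc2ccc(Cl)cc2)ncc1[N+](=O)[O-]` likewise gives only the limit > 100000 nM.

Compound 3 thus stands at the ceiling described by the limit of > 100000 nM in this assay, at which 2 of the 3 values shown sit; its value is a limit, not a number. Compound 4 `CCOC(=O)CN(Cc1ccccc1)c1nc(Nc2cccc(OC)c2)ncc1[N+](=O)[O-]` differs from it by 3-methoxyphenyl in place of 4-chlorophenyl on a nitrogen on an aromatic ring. Among the measured compounds shown here, the steps that bear on this change are an at least 1.7-fold higher number from compound 1 to compound 3 (0.24 log units; that floor lies within the scatter) and a step that the two limits leave unreadable from compound 2 to compound 3; neither can be read as a gain, and both arylamines measured so far sit at the limit. For compound 4 the expected step is a number no higher from compound 3 to compound 4 (the limit leaves the size open), that is, nothing beyond the scatter. Compound 4 is estimated at 100000 nM, with a range from 40000 nM to 300000 nM, and most likely again only a limit.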

Compound 4, half-maximal inhibitory concentration: > 100000 nM
Compound 4: only a limit was reported; the forecaster's own chance of this, stated with the estimate: 60%; the middle value sits exactly at the limit.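

Compound 4 is a third member with an aromatic ring directly on this nitrogen to give only a limit in this assay, so the 3-methoxyphenyl group, like 4-chlorophenyl and 3,4,5-trimethoxyphenyl, yields no measurable number: the limit of > 100000 nM in this assay, at which 3 of the 4 values shown sit. Against the 3-methoxybenzyl group, the only readable comparison is an at least 1.7-fold higher number from compound 1 to compound 4 (0.24 log units; that floor lies within the scatter), so removing the ring's separation from the nitrogen is not shown to matter beyond the scatter. The steps among compound 2, compound 3 and compound 4 cannot be read, as all three values are limits.

From the compounds shown here alone, whether the benzyl-type link matters therefore remains open. Also open, going by these compounds, is how a carboxylic acid in place of the ethyl ester, or a morpholine on this nitrogen, would read in this assay.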